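Heteroaryl swaps on the benzyl arm of the urea series

This account rests on a few compounds, and the source may have more. Where it says the series, first, only, none or still open, it means among the compounds named here.

Measured so far in a functional assay on a cell-free system (plasma) with sterol O-acyltransferase, Soat (Rattus norvegicus) as the target; on this read-out higher numbers stand for an effect only at larger amounts of compound and lower numbers for an effect already at smaller amounts:
compound 1, `Cc1cc(C)c(NC(=O)N(Cc2ccc(-c3cccs3)cc2)C2CCCCCC2)c(C)c1`, 0.28 mg/kg
compound 2, `Cc1cc(C)c(NC(=O)N(Cc2ccc(-c3cnn(C)c3)cc2)C2CCCCCC2)c(C)c1`, 0.31 mg/kg

Going by the values given here, compound 2 holds the higher of the two numbers, but its only neighbour is compound 1, and the gap a 1.1-fold higher number from compound 1 to compound 2 (0.04 log units; within the scatter) lies within the scatter, so the two compounds cannot be ordered on this assay.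

The next compound, compound 3, `Cc1cc(C)c(NC(=O)N(Cc2ccc(-n3nccn3)cc2)C2CCCCCC2)c(C)c1`, carries the change (2H-1,2,3-triazol-2-yl in place of 1-methyl-1H-pyrazol-4-yl on an aromatic carbon), on an aromatic carbon of the six-membered carbon ring, para to a large group. Among the compounds with values here, the one measured step that bears on it is the earlier heteroaryl exchange at the same position, a 1.1-fold higher number from compound 1 to compound 2 (0.04 log units; within the scatter), which produced no shift beyond the scatter. A further exchange of one five-membered heteroaromatic ring for another is therefore expected to stay within the scatter as well, with the step of a 1.1-fold higher number from compound 2 to compound 3 (0.05 log units; within the scatter) set close to nil.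

Compound 3 is estimated at 0.35 mg/kg, with a range from 0.15 mg/kg to 0.8 mg/kg.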

Compound 3, dose for half-maximal effect: > 1 mg/kg
Compound 3: no number, only a limit (the forecaster's own chance of this, stated with the estimate: 10%); middle value at least 2.8-fold (0.45 log units) from the limit.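

Working notes on the benzyl arm: in this assay, the heteroaryl group at this place, on an aromatic carbon para to a large group, is not freely exchangeable, as shown by an at least 3.2-fold higher number from compound 2 to compound 3 (0.50 log units; beyond the scatter) and by an at least 3.5-fold higher number from compound 1 to compound 3 (0.55 log units; beyond the scatter). Compound 1 and compound 2 could not be ordered, so 2H-1,2,3-triazol-2-yl is the first group shown here to move the read-out beyond the scatter, although only one five-membered aromatic ring replaces another. The entry for compound 3 is a limit of the assay and not a number: the limit of > 1 mg/kg in this assay, at which 1 of the 3 values shown sits.

From the compounds shown here alone, how far compound 3 lies past that limit remains open, so the full size of both steps is unknown. Also open, going by these compounds, is whether a plain phenyl or a morpholine at this place would group with thiophen-2-yl or with 2H-1,2,3-triazol-2-yl.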